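Swapping the Indole for an Aminophenyl Sulfide

The compounds below may be only part of what the source reports. "The series", "measured", "known", "first", "only" and "open" are said of these compounds alone.

Compound 1 `Cc1cc(-c2ccc3[nH]ccc3c2)cn2c(CSCCc3ccccc3)cnc12` is tested in an ADME assay on HEL cells (Homo sapiens) for cytotoxicity, with a stated time of 3 days (a lower number here means that less compound is tolerated, a higher number that more compound is tolerated), where compound 1 gives 26 ug/mL. Of the two numbers shown, compound 1 stands at the top, although its only neighbour, compound 2 `Cc1cc(-n2ccc3ccccc32)cn2c(CSCCc3ccccc3)cnc12`, which in this assay gives 18 ug/mL, sits within the scatter of it. Among the compounds with values here, the single measured step, a 1.4-fold lower number from compound 1 to compound 2 (0.16 log units; within the scatter), puts 1H-indol-1-yl in place of 1H-indol-5-yl on an aromatic carbon and does not reach beyond the scatter. Compound 3 `Cc1cc(Sc2ccc(N)cc2)cn2c(CSCCc3ccccc3)cnc12` departs from compound 1 in a different way: (4-aminophenyl)sulfanyl in place of 1H-indol-5-yl on an aromatic carbon. Within the data shown here, no measured step covers this exchange of (4-aminophenyl)sulfanyl for 1H-indol-5-yl, and the one step that changes the group on that aromatic carbon left the number essentially where it was. For compound 3 the expected step is therefore a 1.0-fold lower number from compound 1 to compound 3 (0.02 log units; within the scatter), none beyond the scatter. Compound 3 is estimated at 25 ug/mL in this assay, with a range from 10 ug/mL to 60 ug/mL.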

Compound 3, half-maximal cytotoxic concentration: 23 ug/mL
Beside the measured number, compound 3's estimate is 1.1-fold (0.04 log units) above it; low and high end bracket the measured number.
By their numbers in this assay, from the lowest: compounds 2, 3 and 1 (each within the scatter of the next).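

In this assay, (4-aminophenyl)sulfanyl on this aromatic carbon gives a 1.1-fold lower number from compound 1 to compound 3 (0.05 log units; within the scatter) and, set against the other indole, a 1.3-fold higher number from compound 2 to compound 3 (0.11 log units; within the scatter). This position has now carried three different groups, one of them with a sulfur atom and a single six-membered aromatic ring in place of the fused rings of an indole, and all three compounds still lie within the scatter of one another. Nothing measured here accounts for this narrow spread.

As far as these compounds go, what a carboxylic acid or a short alkyl chain placed directly on this carbon would do to the number stays open. So does the part played by the sulfur atom on its own, as distinct from the aminophenyl ring it carries.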